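Swapping Fluoro for Methyl on a Shared Core

This account rests on a few compounds, and the source may have more. Where it says the series, first, only, none or still open, it means among the compounds named here.

Compound 1: `Cc1cc(-c2nc3cc(F)ccc3o2)ccc1NC(=O)CCl`, 16600 nM
Compound 2: `Cc1cc(-c2nc3ccccc3o2)ccc1NC(=O)CN1CCN(CCN(C)C)CC1`, 19900 nM

Both numbers come from a functional assay on HepG2 cells (Homo sapiens) for cytotoxicity, read by MTT assay, with a stated time of 24 h; on this read-out lower numbers stand for stronger inhibition and higher numbers for weaker inhibition. Compound 1 has the lowest of the two numbers, yet compound 2 lies only slightly higher, and that gap falls within the scatter of repeated measurements, so the two cannot be told apart on these data.

Compound 3, `Cc1ccc2oc(-c3ccc(NC(=O)CCl)c(C)c3)nc2c1`, has not yet been measured. It differs from compound 1 in one place: methyl in place of fluoro on an aromatic carbon. Nothing else in the molecule moves; the chloroacetamide side and the rest of the fused core stay as they are in compound 1.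

Within the data shown here, no pair of measured compounds shows what this exchange does. Among the measured compounds shown here, with only two compounds in hand, and those two within the scatter of each other, there is no basis for expecting a large shift in either direction. The step from compound 1 to compound 3 is therefore expected to be small, a 1.1-fold higher number from compound 1 to compound 3 (0.04 log units; within the scatter), and not beyond the scatter. For compound 3 the estimate in this assay is 18000 nM, with a plausible range from 8000 nM to 40000 nM.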

Compound 3, half-maximal inhibitory concentration: 54800 nM
Estimate against measurement, compound 3: 3.0-fold (0.48 log units) below; the whole stated range lies below it.
By their numbers in this assay, from the lowest: compounds 1 and 2 (each within the scatter of the next); then compound 3.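

In this assay, the exchange of fluoro for methyl on an aromatic carbon of the shared core gives a 3.3-fold higher number from compound 1 to compound 3 (0.52 log units; beyond the scatter), so this position is not indifferent to what sits on it. The size of the step is notable, as each group counts one heavy atom and neither brings a ring, a hydrogen-bond donor or acceptor, or a net charge. Among these compounds, compound 1 and compound 2 differ in more than one place, so only this new step isolates the position, and no measurement in hand bears on the reason for it.

Going by these compounds, whether the step reflects a gain from fluoro or a loss from methyl remains open, and a hydrogen, a chloro, a methoxy or an amine on the same aromatic carbon would help to separate the two. On these data alone, it is also open whether the exchange would give a similar step with the longer side chain of compound 2 in place of the chloroacetamide side.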